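A few compounds are considered here, and "the series" means these few. Any claim that something is new, unique, unknown or untested is made for them only; others in the source may bear on it.

Measured so far:
- compound 1, `O=C1N=C(Nc2ccccc2)S/C1=C/c1ccc(N2CCNCC2)cc1` — > 100000 nM in a functional assay on H460/TaxR cells (Homo sapiens) for cytotoxicity, read by sulforhodamine B assay, with a stated time of 48 h; a higher number here means that more compound is needed for the effect, a lower number that less compound is needed
- compound 2, `CCN(CC)c1ccc(/C=C2/SC(N(c3ccccc3)c3ccccc3)=NC2=O)cc1` — > 100000 nM in this assay

Compound 1 reaches only the limit of this assay, its value of > 100000 nM being a limit and not a number. Compound 2 likewise stands at a limit, giving > 100000 nM in this assay. Both of the two values shown therefore sit at the same limit, as summed up in the limit of > 100000 nM in this assay, at which 2 of the 2 values shown sit; nothing places compound 2 anywhere but at that boundary.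

Compound 3, `O=C1N=C(N(c2ccccc2)c2ccccc2)S/C1=C/c1ccc(N2CCNCC2)cc1`, has not been measured in this assay. It differs from compound 2 in one place: piperazin-1-yl in place of diethylamino on an aromatic carbon. Among the measured compounds shown here, no step between measured compounds is available to guide this change. Since compound 1, which carries the same piperazin-1-yl group, also sits at the limit, compound 3 is expected to remain there as well, with an expected step of a number no higher from compound 2 to compound 3 (the limit leaves the size open). The estimate for compound 3 is 100000 nM, within a range from 30000 nM to 300000 nM.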

Compound 3, half-maximal effective concentration: > 100000 nM
Compound 3: no number, only a limit (the forecaster's own chance of this, stated with the estimate: 85%); the middle value sits exactly at the limit.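

Compound 3 gives > 100000 nM in this assay, which is a limit and not a number, so its steps to compound 1 and compound 2 cannot be read. The compounds shown leave open whether any change to the shared core would give a readable value in this assay.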